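A Single Double Bond Reversed in Compound 2

A few compounds are considered here, and "the series" means these few. Any claim that something is new, unique, unknown or untested is made for them only; others in the source may bear on it.

Compound 1 (`CCCc1cn(C/C=C(\C)CCC=C(C)C)nn1`) gives 4.5
Compound 2 (`CCCc1cn(C/C=C(/C)CC/C=C(\C)CCC=C(C)C)nn1`) gives 6.5

In a physicochemical assay for lipophilicity, measured as octanol-water partition (on this read-out lower numbers stand for lower lipophilicity and higher numbers for higher lipophilicity), compound 2 stands highest of the two measured compounds, and its gap to compound 1 lies beyond the usual scatter. Compound 3 (`CCCc1cn(C/C=C(\C)CC/C=C(\C)CCC=C(C)C)nn1`) has yet to be measured. The change that leads to it is the two compounds have the same atoms and bonds and differ only in configuration as drawn: 1 of 2 stereo elements differ; a double bond is drawn Z in compound 2 and E in compound 3, with a double bond drawn Z in compound 2 and E in compound 3. Among the measured compounds shown here, no measured pair here isolates a change of configuration, so the data offer no direct precedent. Compound 3 keeps every atom and bond of compound 2, which stands at 6.5, so no step beyond the scatter is expected in this assay, in either direction. The expected change is no change at the digits printed from compound 2 to compound 3 (within the scatter), within the scatter. For compound 3 the estimate is 6.5, with an expected range from 6.1 to 6.9 in this measurement.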

Compound 3, partition coefficient: 6.5
Estimate against measurement, compound 3: no gap at the digits printed; low and high end bracket the measured number.
By their numbers in this assay, from the lowest: compound 1; then compounds 2 and 3 (each within the scatter of the next).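

Reversing this double bond gives no change at the digits printed from compound 2 to compound 3 (within the scatter) in this assay, so at this position the configuration as drawn leaves the read-out in place. That pair reads as a clean test of configuration alone because nothing else separates the two structures: the fact that compounds 2 and 3 differ only in the configuration as drawn. The other new pair isolates a change of constitution, and 3-methylbut-2-en-1-yl in place of hydrogen on a saturated chain carbon bound to a double-bonded chain carbon gives a number 2.00 log units higher from compound 1 to compound 3 (beyond the scatter), a large step that the two earlier compounds, with no step listed between them, did not provide.

On these data alone, whether reversing any other double bond in the chain would also leave the number in place remains open. So does the outcome of putting a carboxylic acid, an amine or a longer saturated chain in place of the 3-methylbut-2-en-1-yl.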